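Moving the amino group: 4-aminophenyl to 3-aminophenyl

The source may hold more compounds than are shown below. What is called first, only, known or untested is meant among the compounds shown, and "the series" means these compounds.

In a functional assay on A549 cells (Homo sapiens) for antiproliferative activity, read by MTT assay, with a stated time of 48 h (a lower number here means a stronger inhibitor, a higher number a weaker inhibitor), compound 3 (`COc1cc(-c2cccc3nc(-c4ccc(N)cc4)oc23)cc(OC)c1OC`) gives 720 nM, the lowest of the three numbers. Compound 1 (`COc1cc(-c2cccc3nc(-c4cccc(F)c4)oc23)cc(OC)c1OC`) gives 2600 nM and compound 2 (`COc1cc(-c2cccc3nc(-c4ccc(Cl)cc4)oc23)cc(OC)c1OC`) gives 5600 nM. Compound 4 (`COc1cc(-c2cccc3nc(-c4cccc(N)c4)oc23)cc(OC)c1OC`) is the next case: 3-aminophenyl in place of 4-aminophenyl on an aromatic carbon, with 3-aminophenyl in place of 4-aminophenyl. For the measured compounds named here, no measured step isolates this change. The nearest are a 3.6-fold lower number from compound 1 to compound 3 (0.56 log units; beyond the scatter) and a 7.8-fold lower number from compound 2 to compound 3 (0.89 log units; beyond the scatter), both modest and both replacing the group that carries the amino function, while a 2.2-fold higher number from compound 1 to compound 2 (0.33 log units; beyond the scatter) is also modest. Compound 4 keeps the amino group, so only a partial loss of the gain seen with compound 3 seems likely. The expected step in this assay is a 1.8-fold higher number from compound 3 to compound 4 (0.26 log units; within the scatter), towards a higher number. For compound 4 the estimated value is 1300 nM, within an expected range of 450 nM to 3500 nM.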

Compound 4, half-maximal inhibitory concentration: 4700 nM
Compound 4: middle estimate off by 3.6-fold (0.56 log units), on the low side; the measured number lies above the stated range.
By their numbers in this assay, from the lowest: compound 3; then compounds 1, 4 and 2 (each within the scatter of the next, the first and the last beyond it).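

In this assay, the position of the amino group matters: moving from 4-aminophenyl to 3-aminophenyl gives a 6.5-fold higher number from compound 3 to compound 4 (0.81 log units; beyond the scatter) and removes the advantage of compound 3, so the presence of an amino group alone does not account for it. At the same ring position, amino in place of fluoro gives a 1.8-fold higher number from compound 1 to compound 4 (0.26 log units; within the scatter) and the change from 4-chlorophenyl gives a 1.2-fold lower number from compound 2 to compound 4 (0.08 log units; within the scatter) in the same assay, so compound 4 is not separated from either halogen compound. No evidence on the cause of the positional effect is available here.

As far as these compounds go, whether the low number of compound 3 depends on the amino group itself remains open. A hydroxyl or dimethylamino group on the same phenyl ring could test this.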